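The source may hold more compounds than are shown below. What is called first, only, known or untested is meant among the compounds shown, and "the series" means these compounds.

Compound 1 `Cc1n[nH]c2c1C(c1ccc(N(C)C)cc1)C(C(=O)n1ncc(C#N)c1N)=C(N)N2`: 62700 nM
Compound 2 `Cc1n[nH]c2c1C(c1ccc(N(C)C)cc1)C(C(=O)N/N=C/c1ccc(Cl)cc1)=C(N)N2`: 25200 nM

In a functional assay on MCF7 cells (Homo sapiens) for cytotoxicity, read by MTT assay, with a stated time of 48 h (on this read-out higher numbers stand for weaker inhibition and lower numbers for stronger inhibition), compound 2 holds the lower of the two numbers, at 25200 nM, and so shows the stronger inhibition of the pair. Compound 3 `Cc1n[nH]c2c1C(c1ccc(N(C)C)cc1)C(C(=O)O)=C(N)N2` keeps the shared core but changes the group on the same carbonyl carbon: one oxygen atom in place of a group of 10 heavy atoms (7 carbon, 2 nitrogen, 1 chlorine; one six-membered aromatic ring of carbon only), on a carbonyl carbon. A hydroxy group thus takes the place of the group carrying the six-membered aromatic ring. Going by the values given here, only one measured step bears on this change, a 2.5-fold lower number from compound 1 to compound 2 (0.40 log units; beyond the scatter), which is modest but beyond the scatter. Neither measured compound carries a group as small as hydroxy, so this is a loose guide. A modest move towards a higher number, and so weaker inhibition, is expected, and the estimated step is a 2.0-fold higher number from compound 2 to compound 3 (0.30 log units; within the scatter). For compound 3 the estimate is 50000 nM, with an expected range from 18000 nM to 140000 nM.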

Compound 3, half-maximal inhibitory concentration: 22000 nM
Estimate against measurement, compound 3: 2.3-fold (0.36 log units) above; the measured number falls inside the stated range.
By their numbers in this assay, from the lowest: compounds 3 and 2 (each within the scatter of the next); then compound 1.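

In this assay, hydroxy on the carbonyl carbon in place of the group carrying the six-membered aromatic ring gives a 1.1-fold lower number from compound 2 to compound 3 (0.06 log units; within the scatter) and so leaves the two compounds indistinguishable, even though the group of 10 heavy atoms gives way to a single oxygen atom. The change from 5-amino-4-cyano-1H-pyrazol-1-yl to hydroxy gives a 2.9-fold lower number from compound 1 to compound 3 (0.45 log units; beyond the scatter) and places compound 1 apart from both other compounds, so among these three the number does not follow the size of the group at this position. No measurement given here explains why these groups compare as they do. The compounds shown leave open whether an amine or a methyl ester on this carbonyl carbon would stand with compound 2 and compound 3 or with compound 1. They also leave open whether a primary amide would do the same.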